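Pyrazine hydrazone series: cytotoxicity notes, compound 2 to compound 4

The source may hold more compounds than are shown below. What is called first, only, known or untested is meant among the compounds shown, and "the series" means these compounds.

Measured so far:
- Compound 1 `O=C(N/N=C/c1ccccc1)c1cnccn1`: 75%
- Compound 2 `O=C(N/N=C/c1ccc(Cl)cc1)c1cnccn1`: 64%
- Compound 3 `O=C(N/N=C/c1cccc(F)c1)c1cnccn1`: 46%

In an ADME assay on J774 cells (Mus musculus) for cytotoxicity, read by MTT assay, with a stated time of 48 h, tested at 100 ug/mL (on this read-out lower numbers stand for a stronger effect and higher numbers for a weaker effect at the one concentration tested), compound 2 stands second highest of the three numbers, with compound 1 higher by a number 11 percentage points lower from compound 1 to compound 2 (beyond the scatter) and compound 3 lower, the gap to compound 3 being beyond the scatter. Compound 4 `O=C(N/N=C/c1ccc(F)cc1)c1cnccn1` differs from compound 2 as follows: fluoro in place of chloro on an aromatic carbon.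

Among the measured compounds shown here, no measured step swaps one halogen for another. For the measured compounds named here, the steps that bear on it both start from compound 1: adding chloro gave a number 11 percentage points lower from compound 1 to compound 2 (beyond the scatter), while adding fluoro gave a number 29 percentage points lower from compound 1 to compound 3 (beyond the scatter). Both halogens therefore lowered the number in this assay, the fluoro-bearing compound 3 more so than the chloro-bearing compound 2. Compound 3 and compound 4 are different compounds, so the larger drop cannot simply be transferred.

The expectation for compound 4 is a modest decrease, a number 9 percentage points lower from compound 2 to compound 4 (within the scatter), sitting between the two measured halogen compounds. The estimate for compound 4 in this assay is 55%, with a range from 40% to 72%.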

Compound 4, a percentage reported as activity, at one concentration (the size of the read-out at that concentration, not a potency): 69%
Beside the measured number, compound 4's estimate is 14 percentage points below it; the range from low to high includes it.
By their numbers in this assay, from the lowest: compound 3; then compounds 2, 4 and 1 (each within the scatter of the next, the first and the last beyond it).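

In this assay fluoro in place of chloro on the aromatic carbon para to a large group gives a number 5 percentage points higher from compound 2 to compound 4 (within the scatter) and so does not separate the two halogens at this position. Fluoro there also stays close to the unsubstituted parent, with a number 6 percentage points lower from compound 1 to compound 4 (within the scatter) set against a number 11 percentage points lower from compound 1 to compound 2 (beyond the scatter) for chloro at the same place. The step of a number 29 percentage points lower from compound 1 to compound 3 (beyond the scatter) therefore does not follow from fluoro alone, since it does not recur at this position.

As far as these compounds go, whether an amine, a methoxy group or a carboxylic acid at this position would stay in the same range remains open, as does whether chloro in the place fluoro holds in compound 3 would match that compound. Nothing at hand accounts for these steps.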